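Cytotoxicity notes on an amide series ahead of compound 4

This account rests on a few compounds, and the source may have more. Where it says the series, first, only, none or still open, it means among the compounds named here.

The series shares one core carrying an ester or an amide. Compound 1 `CC(Oc1ccc(Cl)cc1Cl)C(=O)OCc1ccc(F)cc1` in an ADME assay on CHO cells (Cricetulus griseus) for cytotoxicity, read by LDH release (a higher number here means a weaker inhibitor, a lower number a stronger inhibitor), has "not determined" (no result reported). Compound 2 `CC(Oc1ccc(Cl)cc1Cl)C(=O)NCc1cccc(F)c1` in this assay gives 27000 nM. Compound 3 `CC(Oc1ccc(Cl)cc1Cl)C(=O)NCc1ccc2c(ccn2C)c1` in this assay gives 6300 nM. Within the data shown here, of the two numbers known, compound 2 holds the higher one, and the gap between compound 2 and compound 3 lies beyond the usual scatter, so compound 2 is the weaker inhibitor of the two measured compounds.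

Compound 4 `CC(Oc1ccc(Cl)cc1Cl)C(=O)NCc1ccc(F)cn1` has not been measured in this assay. It differs from compound 2 in one place: 5-fluoropyridin-2-yl in place of 3-fluorophenyl on a saturated chain carbon bound to an amide-type nitrogen. Among the measured compounds shown here, no measured pair follows exactly this exchange, so there is no step to lean on, and the two measured values give no direction for it. The expectation is therefore a step no larger than the scatter, with the direction open, which in numbers means an expected step of a 1.1-fold higher number from compound 2 to compound 4 (0.05 log units; within the scatter). On that basis compound 4 is expected to give about 30000 nM in this assay, with a likely range from 12000 nM to 75000 nM. A value reported only as a limit, as can happen with weak inhibitors in this read-out, is a real possibility for compound 4.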

Compound 4, half-maximal inhibitory concentration: > 100000 nM
Compound 4 gave a limit, no number (the forecaster's own chance of this, stated with the estimate: 25%); middle value at least 3.3-fold (0.52 log units) away from the limit.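

Among these compounds, this position is not indifferent in this assay: 5-fluoropyridin-2-yl in place of 3-fluorophenyl on a saturated chain carbon bound to an amide-type nitrogen gives an at least 3.7-fold higher number from compound 2 to compound 4 (0.56 log units; beyond the scatter), the first single exchange that can be read. In this assay compound 4 gives > 100000 nM, which is a limit of the assay and not a number. The entering group carries a ring nitrogen and a hydrogen-bond acceptor that 3-fluorophenyl lacks, and the reading of this step rests on a single point at the edge of the read-out: the limit of > 100000 nM in this assay, at which 1 of the 4 values shown sits.

The compounds shown do not separate the ring nitrogen from the changed place of the fluorine, so the share of each in the step remains open. Also open, as far as these compounds go, is how this assay responds at this position to plain pyridin-2-yl without fluorine, to an aryl group carrying an amine or a carboxylic acid, or to a longer chain between the amide nitrogen and the ring.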